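This account rests on a few compounds, and the source may have more. Where it says the series, first, only, none or still open, it means among the compounds named here.

Measured compounds:
compound 1 `CCCC(=O)N1CC2CC(C1)N2` – 850 nM
compound 2 `CC(C)C(=O)N1CC2CC(C1)N2` – 20000 nM
compound 3 `O=C([C@H]1C[C@H]1F)N1CC2CC(C1)N2` – 1500 nM

In an assay on SH-EP1 cells for agonist activity at Neuronal acetylcholine receptor; alpha4/beta2 (Homo sapiens), read by FLIPR and calcium flux (on this read-out higher numbers stand for an effect only at larger amounts of compound and lower numbers for an effect already at smaller amounts), compound 3 gives the second highest of these three numbers: it sits close to compound 1, within the scatter, and far from compound 2, as a 13-fold lower number from compound 2 to compound 3 (1.12 log units; beyond the scatter) shows. Compound 4 `C[C@@H]1C[C@@H]1C(=O)N1CC2CC(C1)N2` differs from compound 3 in one place: methyl in place of fluoro on a saturated ring carbon. Within the data shown here, no measured step swaps these two groups on the three-membered ring; the large steps seen, a 24-fold higher number from compound 1 to compound 2 (1.37 log units; beyond the scatter) and a 13-fold lower number from compound 2 to compound 3 (1.12 log units; beyond the scatter), concern what is attached to the carbonyl carbon itself, and the small step of a 1.8-fold higher number from compound 1 to compound 3 (0.25 log units; within the scatter) shows the ring group standing near the propyl chain. Since the carbonyl-attached three-membered ring is kept, only a step within the scatter is expected, no change at the digits printed from compound 3 to compound 4 (within the scatter). The estimate for compound 4 is 1500 nM, expected between 500 nM and 5000 nM.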

Compound 4, half-maximal effective concentration: 3800 nM
Compound 4: middle estimate off by 2.5-fold (0.40 log units), on the low side; the range from low to high includes it.
By their numbers in this assay, from the lowest: compounds 1 and 3 (each within the scatter of the next); then compound 4; then compound 2.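

In this assay, among these compounds, the ring substituent itself proves to matter: methyl in place of fluoro on the saturated ring carbon moves the number beyond the scatter (a 2.5-fold higher number from compound 3 to compound 4 (0.40 log units; beyond the scatter)), whereas the earlier steps changed only the whole group on the carbonyl carbon. Keeping the three-membered ring therefore does not by itself hold the number level with the propyl chain (a 4.5-fold higher number from compound 1 to compound 4 (0.65 log units; beyond the scatter)), although the methyl-bearing ring still stays well clear of isopropyl (a 5.3-fold lower number from compound 2 to compound 4 (0.72 log units; beyond the scatter)).

From the compounds shown here alone, whether chloro, hydroxyl or an amine on that ring carbon would fall nearer fluoro or methyl remains open. Nothing shown here gives a reason for the difference between fluoro and methyl.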